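The compounds below may be only part of what the source reports. "The series", "measured", "known", "first", "only" and "open" are said of these compounds alone.

Working notes on the sulfonyl aryl series.

All compounds share one core and differ only in the aryl group on the sulfonyl sulfur. Compound 1 `COc1ccc(-c2cc(=O)c3c(OC)cc(OC)cc3n2S(=O)(=O)c2ccc(C=O)cc2)cc1` carries a 4-formylphenyl; in a functional assay on SUP-B15 cells (Homo sapiens) for antiproliferative activity, with a stated time of 72 h (on this read-out higher numbers stand for an effect only at larger amounts of compound and lower numbers for an effect already at smaller amounts), compound 1 gives only a limit of > 34400 nM, (the limit of > 34400 nM in this assay, at which 1 of the 3 values shown sits). Compound 2 `COc1ccc(-c2cc(=O)c3c(OC)cc(OC)cc3n2S(=O)(=O)c2ccc([N+](=O)[O-])cc2)cc1`, with nitro in place of formyl on that aromatic carbon, gives 17100 nM in this assay. Compound 3 `COc1ccc(-c2cc(=O)c3c(OC)cc(OC)cc3n2S(=O)(=O)c2ccc(C#N)cc2)cc1`, with cyano in place of formyl, gives 7900 nM and stands lowest of the two numbers, with compound 2 as its nearest neighbour.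

The measured steps are an at least 2.0-fold lower number from compound 1 to compound 2 (0.30 log units; that floor lies within the scatter), an at least 4.3-fold lower number from compound 1 to compound 3 (0.63 log units; beyond the scatter) and a 2.2-fold lower number from compound 2 to compound 3 (0.34 log units; beyond the scatter); each exchanges one substituent on the phenyl and moves this assay by no more than a modest amount.

Compound 4 `COc1ccc(-c2cc(=O)c3c(OC)cc(OC)cc3n2S(=O)(=O)c2cc(F)c(F)c(F)c2)cc1` is not yet measured. Its change from compound 3 is 3,4,5-trifluorophenyl in place of 4-cyanophenyl on a sulfonyl sulfur. Among the measured compounds shown here, no measured step replaces the whole aryl group, and the three known steps span only a narrow range, so the expected step is a 1.5-fold higher number from compound 3 to compound 4 (0.18 log units; within the scatter), with the direction uncertain. Compound 4 is therefore estimated at 12000 nM, with an expected range from 3500 nM to 40000 nM.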

Compound 4, half-maximal effective concentration: > 65500 nM
Compound 4: only a limit was reported; the forecaster's own chance of this, stated with the estimate: 30%; at least 5.4-fold (0.73 log units) between middle value and limit.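

Up to compound 3, the changes exchanged one substituent on the phenyl; replacing the whole aryl group on the sulfonyl sulfur with 3,4,5-trifluorophenyl gives an at least 8.2-fold higher number from compound 3 to compound 4 (0.91 log units; beyond the scatter) and an at least 3.8-fold higher number from compound 2 to compound 4 (0.58 log units; beyond the scatter) in this assay, so this position does not accept every aryl group equally. The reading for compound 4 is a limit, not a number: the limit of > 65500 nM in this assay, at which 1 of the 4 values shown sits. The step that links compound 1 and compound 4 cannot be read, since both readings are limits.

Compound 4 gains the three fluorines and loses the nitrile in one change, so the compounds shown do not separate the two. Also open, from the compounds shown here alone, is whether a phenyl with a single fluorine, an amine or a carboxylic acid at this sulfonyl sulfur would fall nearer compound 3 or compound 4.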